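The source may report more compounds than this note shows. Statements on the series, on what has been measured and on what is new or still open speak of the compounds shown alone.

In an ADME assay on MCF7 cells (Homo sapiens) for cytotoxicity, read by MTT assay, with a stated time of 48 h (on this read-out higher numbers stand for weaker inhibition and lower numbers for stronger inhibition), compound 1 (`Fc1ccc(-c2[nH]c3cc(F)ccc3c2Cn2ccnc2)cc1`) gives 83200 nM and compound 2 (`Fc1ccc(-c2[nH]c3cc(Cl)ccc3c2Cn2ccnc2)cc1`) gives 41500 nM. Compound 3 (`Fc1ccc(-c2[nH]c3cc(F)ccc3c2Cn2cncn2)cc1`) gives only a limit, > 1000000 nM, and so stands at the limit of > 1000000 nM in this assay, at which 1 of the 3 values shown sits. Compound 4 (`Fc1ccc(-c2[nH]c3cc(Cl)ccc3c2Cn2cncn2)cc1`) keeps the core and the 1H-1,2,4-triazol-1-yl group of compound 3 and differs from it in one place: chloro in place of fluoro on an aromatic carbon. The same exchange has been measured once, as a 2.0-fold lower number from compound 1 to compound 2 (0.30 log units; within the scatter), and that step does not rise beyond the scatter. The other measured step that bears on compound 4 is an at least 12-fold higher number from compound 1 to compound 3 (1.07 log units; beyond the scatter), a large step that shows how far the 1H-1,2,4-triazol-1-yl group carries the number upward from the 1H-imidazol-1-yl compounds. No step beyond the scatter is therefore expected in this assay for the exchange of fluoro for chloro, and a slightly lower number would be the likeliest direction. The expected outcome is an at least 2.0-fold lower number from compound 3 to compound 4 (0.30 log units; that floor lies within the scatter), although the assay may again report only a limit. The estimate for compound 4 is 500000 nM, with an expected range of 150000 nM to 1000000 nM.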

Compound 4, half-maximal inhibitory concentration: 625000 nM
Compound 4: middle estimate off by 1.3-fold (0.10 log units), on the low side; the range from low to high includes it.
By their numbers in this assay, from the lowest: compounds 2 and 1 (each within the scatter of the next); then compound 4. At a limit, above all of these: compound 3.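

In this assay, the exchange of fluoro for chloro gives an at least 1.6-fold lower number from compound 3 to compound 4 (0.20 log units; that floor lies within the scatter), its first reading on the 1H-1,2,4-triazol-1-yl core and in the same direction as on the 1H-imidazol-1-yl core: the same change on two cores in this assay, a 2.0-fold lower number (0.30 log units; within the scatter) from compound 1 to compound 2 and an at least 1.6-fold lower number (0.20 log units; that floor lies within the scatter) from compound 3 to compound 4; the limit leaves it open whether they differ
The exchange of 1H-imidazol-1-yl for 1H-1,2,4-triazol-1-yl now gives a 15-fold higher number from compound 2 to compound 4 (1.18 log units; beyond the scatter), so its large upward step also appears with chloro on the aromatic carbon, not only with fluoro: the same change on two cores in this assay, an at least 12-fold higher number (1.07 log units; beyond the scatter) from compound 1 to compound 3 and a 15-fold higher number (1.18 log units; beyond the scatter) from compound 2 to compound 4; the limit leaves it open whether they differ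
Compound 3 remains at a limit, so its step to compound 4 has only a floor: the limit of > 1000000 nM in this assay, at which 1 of the 4 values shown sits.

The compounds shown leave open how far the two chloro-for-fluoro steps differ from each other. They also leave open how a methoxy group or a nitrile on the same aromatic carbon would read in this assay.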